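The source may report more compounds than this note shows. Statements on the series, on what has been measured and on what is new or still open speak of the compounds shown alone.

Compound 1 `COC(=O)NC1=NC(c2cccc(C)c2)CN1`: 100 mg/kg
Compound 2 `COC(=O)NC1=NC(c2cccc(Cl)c2)CN1`: 48 mg/kg

Going by the values given here, in a functional assay on the whole organism for antagonist activity, with Mus musculus as the target, in the maximal electroshock model (a lower number here means that less compound is needed, a higher number that more compound is needed for the effect), compound 2 gives 48 mg/kg, the lower of the two numbers so far, so less of it is needed for the effect. Among the compounds with values here, the only other measured compound, compound 1, gives 100 mg/kg.

The next compound, compound 3 `COC(=O)NC1=NC(c2cccc(Br)c2)CN1`, keeps the shared core and changes a single group, with bromo in place of chloro on an aromatic carbon. The group sits on a six-membered aromatic ring of carbon only, meta to a large group.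

Within the data shown here, one measured step bears on this change: a 2.1-fold lower number from compound 1 to compound 2 (0.32 log units; beyond the scatter). Among the measured compounds shown here, that swap of chloro in place of methyl was modest, and it is the only guide, since no bromo compound has been measured yet. With so little evidence, no clear direction can be expected in this assay, and a change beyond the scatter is not expected. The expected step is a 1.1-fold lower number from compound 2 to compound 3 (0.03 log units; within the scatter). For compound 3 the estimated value is 45 mg/kg, with an expected range from 24 mg/kg to 85 mg/kg.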

Compound 3, dose for half-maximal effect: about 68 mg/kg
Beside the measured number, compound 3's estimate is 1.5-fold (0.18 log units) below it, and the stated range covers the measured number.
By their numbers in this assay, from the lowest: compounds 2, 3 and 1 (each within the scatter of the next, the first and the last beyond it).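

In this assay, bromo in place of chloro on this aromatic carbon gives a 1.4-fold higher number from compound 2 to compound 3 (0.15 log units; within the scatter) and so stays within the scatter, which means that these two halogens cannot be told apart at this position. Bromo in place of methyl gives a 1.5-fold lower number from compound 1 to compound 3 (0.17 log units; within the scatter) and also stays within the scatter, so compound 3 cannot be separated from either compound 1 or compound 2, and the only step beyond the scatter remains a 2.1-fold lower number from compound 1 to compound 2 (0.32 log units; beyond the scatter). The bromo result therefore does not show that a halogen at this position generally gives a lower number than methyl, and nothing measured here offers an explanation for any of these steps.

As far as these compounds go, with only methyl, chloro and bromo to compare, it remains open how a plain hydrogen, fluoro, methoxy or trifluoromethyl would behave on this same aromatic carbon. From the compounds shown here alone, it is also open whether chloro or bromo would give similar numbers on another carbon of the ring, and whether the small gap between them would hold with a different group in place of the methyl ester of the shared core.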